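The source may report more compounds than this note shows. Statements on the series, on what has been measured and on what is new or still open speak of the compounds shown alone.

Of the compounds shown here, three built on one shared core have been measured in an assay on HEK293 cells for displacement of a labelled ligand from NPC1-like intracellular cholesterol transporter 1 (Homo sapiens); on this read-out higher numbers stand for weaker inhibition and lower numbers for stronger inhibition. Compound 1, `CCOC(=O)C1CCN(C(=O)CN2CN(c3ccccc3)C3(CCN(C(=O)c4ccc(C5CCCCC5)cc4)CC3)C2=O)CC1`, gives 900 nM there, the lowest of the three numbers. Compound 3, `CC(C)(C)OC(=O)NC1CCCN(C(=O)CN2CN(c3ccccc3)C3(CCN(C(=O)c4ccc(C(C)(C)C)cc4)CC3)C2=O)C1`, gives 4200 nM, and compound 2, `CC(C)(C)c1ccc(C(=O)N2CCC3(CC2)C(=O)N(CC(=O)N2CCN(S(C)(=O)=O)CC2)CN3c2ccccc2)cc1`, gives 19000 nM; the gaps from compound 1 to both of these lie beyond the usual scatter. Compound 2 and compound 3 differ from compound 1 in more than one place, so neither of them isolates a single structural step, and no single-point comparison is available among the measured compounds.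

Compound 4, `COC(=O)CCNC(=O)CN1CN(c2ccccc2)C2(CCN(C(=O)c3ccc(C4CCCCC4)cc3)CC2)C1=O`, differs from compound 1 in one place: (2-(methoxycarbonyl)ethyl)amino in place of 4-(ethoxycarbonyl)piperidin-1-yl on a carbonyl carbon. The ring with its ester is replaced by a shorter open chain that brings one hydrogen-bond donor, while the number of acceptors stays the same. Among the measured compounds shown here, with no measured pair that shows this kind of exchange, the expectation rests on compound 1 alone, and the step of a 2.2-fold higher number from compound 1 to compound 4 (0.35 log units; beyond the scatter) is expected to be a modest weakening, close to the edge of the scatter. Compound 4 is therefore estimated at 2000 nM, with a likely range from 600 nM to 7000 nM.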

Compound 4, half-maximal inhibitory concentration: 12900 nM
The estimate for compound 4 lay 6.5-fold (0.81 log units) below the measured number; the measured number lies above the stated range.
By their numbers in this assay, from the lowest: compound 1; then compound 3; then compounds 4 and 2 (each within the scatter of the next).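

This is the first single-place comparison among the compounds shown: in this assay, (2-(methoxycarbonyl)ethyl)amino in place of 4-(ethoxycarbonyl)piperidin-1-yl on a carbonyl carbon produces a 14-fold higher number from compound 1 to compound 4 (1.16 log units; beyond the scatter) and shows that this position is sensitive to what it carries. An ester is present on both sides of the step, so keeping an ester in the group does not by itself preserve the number of compound 1. No supporting measurement bears on the reason for this loss.

The exchange removes the ring, reduces the heavy-atom count, adds a hydrogen-bond donor and changes ethyl ester to methyl ester all at once, so the compounds shown do not say which of these matters. Nor do they show how an unsubstituted piperidin-1-yl, or a carboxylic acid in place of the ester, would fare on this carbonyl carbon.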